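This account rests on a few compounds, and the source may have more. Where it says the series, first, only, none or still open, it means among the compounds named here.

Measured compounds in this series:

compound 1, `CCOc1ccc(NC(=O)c2cn(-c3ccccc3)nc2-c2ccc(OC)cc2)cc1` — 970 nM
compound 2, `O=C(Nc1ccc(Cl)cc1)c1cn(-c2ccccc2)nc1-c1ccc(Cl)cc1` — 2990 nM

Both were tested in a functional assay on HCT-116 cells (Homo sapiens) for cytotoxicity, read by MTT assay, with a stated time of 48 h; a higher number here means a weaker inhibitor, a lower number a stronger inhibitor. Compound 1 gives 970 nM and compound 2 gives 2990 nM, so compound 2 carries the higher of the two numbers, the weaker of the pair, and the gap to compound 1 is beyond the scatter. The two differ at both aryl positions at once, so neither position can be read on its own from these values.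

Compound 3, `CCOc1ccc(NC(=O)c2cn(-c3ccccc3)nc2-c2ccc(Cl)cc2)cc1`, is not yet measured. It is derived from compound 2 by ethoxy in place of chloro on an aromatic carbon, which leaves the rest of the molecule as in compound 2 and carries over the amide-side aryl of compound 1. No single-point step between measured compounds exists, so the size of this step is uncertain; on the numbers shown the change toward the pattern of compound 1 is more likely to lower the number than to raise it, by a modest amount that may stay within the scatter. For compound 3 the expected value in this assay is 1600 nM, with a range from 600 nM to 4200 nM, corresponding to an expected step of a 1.9-fold lower number from compound 2 to compound 3 (0.27 log units; within the scatter).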

Compound 3, half-maximal inhibitory concentration: 420 nM
Compound 3: middle estimate off by 3.8-fold (0.58 log units), on the high side, and the stated range ends above it.
By their numbers in this assay, from the lowest: compound 3; then compound 1; then compound 2.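

In this assay, the two aryl positions can now be read apart: with the 4-chlorophenyl on the other side of the core held constant, going from (4-chlorophenyl)amino to (4-ethoxyphenyl)amino gives a 7.1-fold lower number from compound 2 to compound 3 (0.85 log units; beyond the scatter) and is beyond the scatter. With the (4-ethoxyphenyl)amino group held constant, chloro in place of methoxy on the other aryl gives a 2.3-fold lower number from compound 1 to compound 3 (0.36 log units; beyond the scatter) and is also beyond the scatter, so both positions affect the number, and compound 3 is the most potent of the three compounds in this cell assay. Nothing measured here bears on why either change lowers the number.

Open is whether the two changes add up, since the series shown lacks the partner with chloro on the amide-side aryl and methoxy on the other aryl, which would complete the set of four. Also open, on these data alone, is how far the amide-side position tolerates other groups, such as methoxy, a longer propoxy chain, an amine or a carboxylic acid, and whether the ethoxy result holds beyond this single cell line.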